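Ether link in place of direct biaryl attachment

A few compounds are considered here, and "the series" means these few. Any claim that something is new, unique, unknown or untested is made for them only; others in the source may bear on it.

Compound 1 `Cc1ccccc1-n1nc(C)c2c1NC(=O)[C@H](C)S[C@@H]2c1ccc(-c2cccc(C(=O)O)c2)cc1` is recorded as "not active" (no number reported) in an assay on isolated protein for agonist activity at Bile acid receptor (Homo sapiens), read by AlphaScreen, with a stated time of 30 min (on this read-out lower numbers stand for an effect already at smaller amounts and higher numbers for an effect only at larger amounts of compound), with no number reported, so on the values shown it has no single standing. Compound 2 `COc1ccc(C2SC(C)C(=O)Nc3c2c(C)nn3-c2ccccc2C)c(OC)c1` in this assay gives 10500 nM. Compound 3 `Cc1ccccc1-n1nc(C)c2c1NC(=O)[C@H](C)S[C@@H]2c1ccc(Oc2cccc(C(=O)O)c2)cc1` carries the change (3-carboxyphenoxy in place of 3-carboxyphenyl on an aromatic carbon). Among the measured compounds shown here, no measured pair covers this change, so the size and direction of the step in this assay are open; at most weak activity is expected, with a real chance that again only a limit is returned. Compound 3 is expected to give 8000 nM in this assay, estimated within 1500 nM to 40000 nM.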

Compound 3, half-maximal effective concentration: "not active" (no number reported)
The entry for compound 3 holds no number; there is nothing to compare the estimate with.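

Compound 1 and compound 3 both return no number, so no step can be read between them. On these data alone, whether 3-carboxyphenoxy in place of 3-carboxyphenyl shifts activity at all stays open. No evidence bears on this result.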